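Swapping a para-ethyl for a meta-methyl on the phenyl ring

The source may hold more compounds than are shown below. What is called first, only, known or untested is meant among the compounds shown, and "the series" means these compounds.

In a functional assay on SK-MEL-5 cells (Homo sapiens) for inhibition, read by sulforhodamine B assay, with a stated time of 48 h, tested at 10 uM (on this read-out lower numbers stand for less inhibition and higher numbers for more inhibition at the one concentration tested (going by the name of the read-out)), compound 3 `CCc1ccc(-c2cn3ccnc3c(-c3ccc4ncn(Cc5ccccc5)c4c3)n2)cc1` gives 47.9%, the highest of the three numbers measured. Among the measured compounds shown here, compound 2 `Brc1ccc(-c2cn3ccnc3c(-c3ccc4ncn(C5CCCCC5)c4c3)n2)cc1` gives 23.6%, and compound 1 `Fc1ccc(-c2cn3ccnc3c(-c3ccc4ncn(C5CCCCC5)c4c3)n2)cc1` gives 7.36%; the one single-point step, a number 16.2 percentage points higher from compound 1 to compound 2 (beyond the scatter), concerns bromo in place of fluoro. Compound 4 `Cc1cccc(-c2cn3ccnc3c(-c3ccc4ncn(Cc5ccccc5)c4c3)n2)c1` differs from compound 3 by 3-methylphenyl in place of 4-ethylphenyl on an aromatic carbon. For the measured compounds named here, no measured step bears directly on this exchange: compound 3 differs from compounds 1 and 2 in two places at once, so the effect of altering the group on the phenyl ring alone remains untested here. A step of modest size is therefore expected, with the direction uncertain and a small loss somewhat more likely, giving an expected a number 9.9 percentage points lower from compound 3 to compound 4 (within the scatter). Compound 4 is estimated at 38%, expected between 15% and 60%.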

Compound 4, a percentage reported as inhibition, at one concentration (the size of the read-out at that concentration, not a potency): 10.1%
Estimate against measurement, compound 4: 27.9 percentage points above, and the stated range ends above it.
By their numbers in this assay, from the lowest: compounds 1 and 4 (each within the scatter of the next); then compound 2; then compound 3.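

With the benzyl-free wording of the change kept simple, the result is this: in this assay, 3-methylphenyl in place of 4-ethylphenyl on the shared core gives a number 37.8 percentage points lower from compound 3 to compound 4 (beyond the scatter), a large step. So this position responds strongly to a change of alkyl group on the phenyl ring, not only to the exchange of one halogen for another seen earlier. No measurement here accounts for the drop.

On these data alone, both the chain and its place on the ring change at once, so which of the two matters stays open. So does the effect of an amine on this ring.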